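A few compounds are considered here, and "the series" means these few. Any claim that something is new, unique, unknown or untested is made for them only; others in the source may bear on it.

Measured in a functional assay on MCF7 cells (Homo sapiens) for cytotoxicity; on this read-out higher numbers stand for weaker inhibition and lower numbers for stronger inhibition:
- Compound 1 `C=C/C=C\[C@H](C)[C@H](OC(N)=O)[C@@H](C)[C@H](O)[C@@H](C)C/C(C)=C\[C@H](C)[C@@H](O)[C@@H](C)/C=C\CCc1cccc(O)c1C`: 1000 nM
- Compound 2 `C=C/C=C\[C@H](C)[C@H](OC(N)=O)[C@@H](C)[C@H](O)[C@@H](C)C/C(C)=C\[C@H](C)[C@@H](O)[C@@H](C)/C=C\CCc1ccccc1`: 560 nM
- Compound 3 `C=C/C=C\[C@H](C)[C@H](OC(N)=O)[C@@H](C)[C@H](O)[C@@H](C)C/C(C)=C\[C@H](C)[C@@H](O)[C@@H](C)/C=C\CCc1cccc(OC)c1`: 500 nM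

These values all lie within the usual scatter of one another, so compound 3 at 500 nM cannot be told apart from compound 1 or compound 2. The next molecule, compound 4 `C=C/C=C\[C@H](C)[C@H](OC(N)=O)[C@@H](C)[C@H](O)[C@@H](C)C/C(C)=C\[C@H](C)[C@@H](O)[C@@H](C)/C=C\CCc1ccsc1`, keeps the shared core and alters only the aromatic end of the chain: thiophen-3-yl in place of 3-methoxyphenyl on a saturated chain carbon, two bonds along the chain from a double-bonded chain carbon. Thiophen-3-yl thus stands in place of 3-methoxyphenyl on a saturated chain carbon, two bonds along the chain from a double-bonded chain carbon.

Three measured steps changed this same end: a 1.8-fold lower number from compound 1 to compound 2 (0.25 log units; within the scatter), a 2.0-fold lower number from compound 1 to compound 3 (0.30 log units; within the scatter) and a 1.1-fold lower number from compound 2 to compound 3 (0.05 log units; within the scatter). Each stayed within the scatter. None of them brings in a five-membered ring, so the data offer no direct reading of this exchange. They also give no reason to expect a real shift in this assay in either direction. The expected step is a 1.1-fold higher number from compound 3 to compound 4 (0.04 log units; within the scatter), which means no change beyond the scatter. For compound 4 the estimated value is 550 nM, with an expected range from 250 nM to 1200 nM.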

Compound 4, half-maximal inhibitory concentration: 4000 nM
The estimate for compound 4 lay 7.3-fold (0.86 log units) below the measured number; the whole stated range lies below it.
By their numbers in this assay, from the lowest: compounds 3, 2 and 1 (each within the scatter of the next); then compound 4.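

In this assay, this end of the chain proves sensitive to at least one exchange: thiophen-3-yl gives a clearly higher number than each of the three substituted or plain phenyl ends (an 8.0-fold higher number from compound 3 to compound 4 (0.90 log units; beyond the scatter); a 7.1-fold higher number from compound 2 to compound 4 (0.85 log units; beyond the scatter); a 4.0-fold higher number from compound 1 to compound 4 (0.60 log units; beyond the scatter)), and all three steps lie beyond the scatter. Going by these compounds alone, the earlier compounds showed only that the phenyl ring on this saturated chain carbon could carry a methoxy group, or a hydroxy and a methyl group, without a measurable shift; compound 4 shows that replacing that six-membered ring with a five-membered, sulfur-containing ring weakens inhibition. No evidence is available on why this happens.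

The compounds shown leave open whether the weaker inhibition follows the ring size, the sulfur or the point of attachment. A furan-3-yl, thiophen-2-yl or pyridin-3-yl end on the same chain could help separate these possibilities.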